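The compounds below may be only part of what the source reports. "The series", "measured", "known", "first", "only" and "open" are said of these compounds alone.

Working notes on the series, read in a functional assay on HT-29 cells (Homo sapiens) for antiproliferative activity, read by MTT assay, with a stated time of 72 h; a higher number here means a weaker inhibitor, a lower number a stronger inhibitor. In this assay compound 1 (`Cc1ccc(N2CCN(C(=S)SCc3ccc4nc(N)nc(N)c4c3)CC2)cc1`) gives 3020 nM, compound 2 (`Nc1nc(N)c2cc(CSC(=S)N3CCN(c4ccccc4Cl)CC3)ccc2n1`) gives 3900 nM and compound 3 (`Nc1nc(N)c2cc(CSC(=S)N3CCN(c4ccc(F)cc4F)CC3)ccc2n1`) gives 5020 nM. Compound 3 thus stands within the scatter of both others, as shown by a 1.3-fold higher number from compound 2 to compound 3 (0.11 log units; within the scatter) and a 1.7-fold higher number from compound 1 to compound 3 (0.22 log units; within the scatter).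

Compound 4 (`CC(=O)c1ccc(N2CCN(C(=S)SCc3ccc4nc(N)nc(N)c4c3)CC2)cc1`) carries 4-acetylphenyl in place of 2,4-difluorophenyl on an amine nitrogen in a ring. The measured steps that bear on this change are exchanges of the group at that same nitrogen. Besides the two above, there is a 1.3-fold higher number from compound 1 to compound 2 (0.11 log units; within the scatter). None of them leaves the scatter. From the compounds shown here alone, none of the three measured compounds carries a carbonyl, however, so the acetyl group itself is untested and the expectation remains loose. No step beyond the scatter is expected in this assay. The estimated value for compound 4 is 4000 nM, with an expected range from 1700 nM to 9500 nM. The expected change is a 1.3-fold lower number from compound 3 to compound 4 (0.10 log units; within the scatter).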

Compound 4, half-maximal inhibitory concentration: 2280 nM
Compound 4: middle estimate off by 1.8-fold (0.24 log units), on the high side; low and high end bracket the measured number.
By their numbers in this assay, from the lowest: compounds 4, 1, 2 and 3 (each within the scatter of the next, the first and the last beyond it).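

In this assay the amine nitrogen in the six-membered ring now gives its first step beyond the scatter, a modest one, with 4-acetylphenyl in place of 2,4-difluorophenyl (a 2.2-fold lower number from compound 3 to compound 4 (0.34 log units; beyond the scatter)). The separation rests on compound 3 alone, since 4-acetylphenyl stays within the scatter of the 2-chlorophenyl group (a 1.7-fold lower number from compound 2 to compound 4 (0.23 log units; within the scatter)) and acetyl in place of methyl on an aromatic carbon also leaves the number within the scatter (a 1.3-fold lower number from compound 1 to compound 4 (0.12 log units; within the scatter)). Going by these compounds alone, no measurement at hand accounts for the one step that leaves the scatter.

From the compounds shown here alone, whether a carbonyl is what counts stays open, as a single acetyl compound cannot separate it from the other changes on the phenyl ring. A carboxylic acid or an amine on that ring, or a pyridine ring in its place, would test how far this position can shift the number.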